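This account rests on a few compounds, and the source may have more. Where it says the series, first, only, none or still open, it means among the compounds named here.

Compound 1 `O=S(=O)(/C=C/c1ccc(F)cc1)Cc1ccc(Nc2ncnc3ccccc23)cc1` gives 1000 nM in a functional assay on HT-29 cells (Homo sapiens); a lower number here means a stronger inhibitor of growth, a higher number a weaker inhibitor of growth. Compound 2 `O=S(=O)(/C=C/c1ccc(Cl)cc1)Cc1ccc(Nc2ncnc3ccccc23)cc1` gives 73000 nM in this assay. Compound 3 `O=S(=O)(/C=C/c1ccc(F)cc1Cl)Cc1ccc(Nc2ncnc3cc(Cl)ccc23)cc1` reaches only the limit of > 100000 nM in this assay, (the limit of > 100000 nM in this assay, at which 1 of the 3 values shown sits).

The change fluoro in place of chloro on an aromatic carbon produced a 73-fold lower number from compound 2 to compound 1 (1.86 log units; beyond the scatter). How the core of compound 3 differs from that of compound 2 is not broken down here. Compound 4 `O=S(=O)(/C=C/c1ccc(F)cc1F)Cc1ccc(Nc2ncnc3cc(Cl)ccc23)cc1` carries the change (fluoro in place of chloro on an aromatic carbon); the surroundings differ, ortho to a large group and meta to a fluoro group rather than para to a large group, so it is the same kind of change, not the same. Compound 4 is expected to show an at least 12-fold lower number from compound 3 to compound 4 (1.09 log units; beyond the scatter) in this assay, resting on the large step of a 73-fold lower number from compound 2 to compound 1 (1.86 log units; beyond the scatter) and on compound 3 being only a limit. Compound 4 is estimated at 8000 nM, between 800 nM and 100000 nM.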

Compound 4, concentration for 50% growth inhibition: > 100000 nM
Compound 4: a limit, no number; the forecaster's own chance of this, stated with the estimate: 25%; at least 12-fold (1.09 log units) between middle value and limit.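

No step can be read from compound 3 to compound 4, since both sit only at a limit: the limit of > 100000 nM in this assay, at which 2 of the 4 values shown sit.

As far as these compounds go, whether fluoro in place of chloro, ortho to a large group, shifts growth inhibition on the core of compound 3 stays open.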